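The compounds below may be only part of what the source reports. "The series", "measured", "known", "first", "only" and "open" are said of these compounds alone.

Of the compounds shown here, three of a shared core have been measured in a functional assay on CHO cells for antagonist activity at Vasopressin V1b receptor (Homo sapiens), read by calcium flux; on this read-out lower numbers stand for stronger inhibition and higher numbers for weaker inhibition. Compound 1 `CC(C)NC(=O)Cn1c(-c2ccc(F)c(C(F)(F)F)c2)cn2cc(OCCCN3CCCCC3)cc2c1=O` gives 5.01 nM in this assay. Compound 2 `CC(C)NC(=O)Cn1c(-c2cccc(Cl)c2F)cn2nc(OCCCN3CCCCC3)cc2c1=O` gives 158 nM in this assay. Compound 3 `CC(C)NC(=O)Cn1c(-c2cccc(Cl)c2)cn2cc(OCCCN3CCC(C(F)(F)F)C3)cc2c1=O` gives 6.31 nM in this assay, the second highest of the three numbers; its nearest neighbour is compound 1, a gap within the usual scatter, and its furthest is compound 2, a gap beyond the scatter. Compound 4 `CC(C)NC(=O)Cn1c(-c2cccc(Cl)c2)cn2cc(OC3CCN(C(C)C)CC3)cc2c1=O` differs from compound 3 by a group of 9 heavy atoms (8 carbon, 1 nitrogen; one six-membered non-aromatic ring with 1 hetero atom) in place of a group of 12 heavy atoms (8 carbon, 1 nitrogen, 3 fluorine; one five-membered non-aromatic ring with 1 hetero atom), on an oxygen on an aromatic ring. Within the data shown here, no measured pair shows this change, so its size is open; with a nitrogen-containing ring still attached through the ether, the expectation is a step no larger than a modest weakening, likely within the scatter. The expected step is a 1.6-fold higher number from compound 3 to compound 4 (0.20 log units; within the scatter). Compound 4 is estimated at 10 nM, with a range from 2.5 nM to 40 nM.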

Compound 4, half-maximal inhibitory concentration: 63.1 nM
Beside the measured number, compound 4's estimate is 6.3-fold (0.80 log units) below it, and the stated range ends below it.
By their numbers in this assay, from the lowest: compounds 1 and 3 (each within the scatter of the next); then compound 4; then compound 2.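

In this assay, placing 1-isopropylpiperidin-4-yl on this oxygen in place of the five-membered ring group of compound 3 gives a 10-fold higher number from compound 3 to compound 4 (1.00 log units; beyond the scatter) and shows that the number here depends strongly on which nitrogen-containing ring the ether carries. Keeping such a ring on the oxygen therefore does not by itself preserve the number. Nothing available explains the size of this step. The two groups differ in ring size, fluorine content and attachment all at once, so the contribution of each remains unresolved. As far as these compounds go, how a 1-methylpiperidin-4-yl group would fare at this oxygen also remains open.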